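Methylamino at the lactam ring carbon of compound 1

The compounds below may be only part of what the source reports. "The series", "measured", "known", "first", "only" and "open" are said of these compounds alone.

Compound 1, `CC[C@H]1C[C@@H](c2c(OC)cccc2OC)N(Cc2ccc(OC(F)(F)F)cc2)C1=O`, carries an ethyl group on a saturated carbon of its five-membered lactam core. In a functional assay on CHO cells for antagonist activity at Orexin/Hypocretin receptor type 1 (Homo sapiens), read by FLIPR and calcium flux (a lower number here means a stronger inhibitor, a higher number a weaker inhibitor), compound 1 gives 619 nM, the highest of the three numbers in hand. Compound 2, `COc1cccc(OC)c1[C@@H]1C[C@H](Cl)C(=O)N1Cc1ccc(OC(F)(F)F)cc1`, with chloro in place of the ethyl, gives 65 nM in this assay, and its configurational partner compound 3, `COc1cccc(OC)c1[C@@H]1C[C@@H](Cl)C(=O)N1Cc1ccc(OC(F)(F)F)cc1`, gives 177 nM.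

For the measured compounds named here, two measured steps touch this position. The exchange of ethyl for chloro gives a 9.5-fold lower number from compound 1 to compound 2 (0.98 log units; beyond the scatter). The change of configuration at the same carbon gives a 2.7-fold higher number from compound 2 to compound 3 (0.44 log units; beyond the scatter), a gap that rests on (the fact that compounds 2 and 3 differ only in the configuration as drawn).

Compound 4, `CN[C@H]1C[C@@H](c2c(OC)cccc2OC)N(Cc2ccc(OC(F)(F)F)cc2)C1=O`, makes the change (methylamino in place of ethyl on a saturated ring carbon). Going by the values given here, the substitution from compound 1 to compound 2 shows that replacing the ethyl at this carbon can lower the number well beyond the scatter, yet methylamino is a different group from chloro and no measured step covers it directly. The step from compound 1 to compound 4 is therefore expected to be a modest lowering, a 2.1-fold lower number from compound 1 to compound 4 (0.31 log units; beyond the scatter), with wide uncertainty. Compound 4 is estimated at 300 nM in this assay, within a range of 60 nM to 1500 nM.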

Compound 4, half-maximal inhibitory concentration: 5780 nM
The estimate for compound 4 lay 19-fold (1.28 log units) below the measured number, outside the stated range (above it).
By their numbers in this assay, from the lowest: compound 2; then compound 3; then compound 1; then compound 4.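

In this assay, the position proves sensitive in both directions: chloro lowers the number relative to ethyl, whereas methylamino, which brings a hydrogen-bond donor and a hydrogen-bond acceptor that ethyl lacks, gives a 9.3-fold higher number from compound 1 to compound 4 (0.97 log units; beyond the scatter). Against chloro, the same group gives an 89-fold higher number from compound 2 to compound 4 (1.95 log units; beyond the scatter), a large step and the widest gap among the single-place changes at this carbon. No measurement in hand explains the rise, and the configurational difference between compounds 2 and 3 does not bear on this change of group.

The compounds shown leave open whether the higher number follows from the ring carbon carrying a nitrogen substituent at all or from the hydrogen on that nitrogen, a question that dimethylamino, an unsubstituted amine and a hydroxyl group at the same carbon would separate. Also open, going by these compounds, is how configuration at this carbon plays out with methylamino, since the gap between compounds 2 and 3 belongs to chloro and compound 4 has no configurational partner among the compounds here.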